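Chloro Joins Fluoro on the Carbamate Aryl Ring

This account rests on a few compounds, and the source may have more. Where it says the series, first, only, none or still open, it means among the compounds named here.

Of the compounds shown here, three on a shared core have been tested. Compound 1 `CC(C)=CCC1Cc2c(O)cc(=O)n(CCCO)c2CC1(C)C` gives 0% in a functional assay on PANC-1 cells (Homo sapiens) for inhibition, read by MTT assay, with a stated time of 24 h, tested at 10 uM; a higher number here means more inhibition at the concentration tested (going by the name of the read-out), a lower number less inhibition. Compound 2 `COc1cccc(NC(=O)Oc2cc(=O)n(CCCO)c3c2CC(CC=C(C)C)C(C)(C)C3)c1` gives 0% in this assay, and compound 3 `CC(C)=CCC1Cc2c(OC(=O)Nc3cccc(F)c3)cc(=O)n(CCCO)c2CC1(C)C` gives 0% in this assay. The steps between them are all flat: no change at the digits printed from compound 1 to compound 2 (within the scatter), no change at the digits printed from compound 1 to compound 3 (within the scatter) and no change at the digits printed from compound 2 to compound 3 (within the scatter). Compound 3 therefore stands level with compounds 1 and 2 at the digits shown, no step among the three rising beyond the scatter.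

Compound 4 `CC(C)=CCC1Cc2c(OC(=O)Nc3ccc(F)c(Cl)c3)cc(=O)n(CCCO)c2CC1(C)C` is the next candidate. It differs from compound 3 in one place: 3-chloro-4-fluorophenyl in place of 3-fluorophenyl on an amide-type nitrogen. The step that bears most directly on this change is no change at the digits printed from compound 2 to compound 3 (within the scatter), a swap of one substituent on the same aryl ring, which moved nothing; no change at the digits printed from compound 1 to compound 3 (within the scatter) shows that adding the whole carbamate likewise moved nothing. On these numbers the expected step is a number 2 percentage points higher from compound 3 to compound 4 (within the scatter), no change beyond the scatter. Compound 4 is estimated at 2%, within a range of 0% to 15%.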

Compound 4, a percentage reported as inhibition, at one concentration (the size of the read-out at that concentration, not a potency): 0%
Estimate against measurement, compound 4: 2 percentage points above; the range from low to high includes it.
By their numbers in this assay, from the lowest: compounds 1, 2, 3 and 4 (each within the scatter of the next).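

In this assay, 3-chloro-4-fluorophenyl in place of 3-fluorophenyl on the amide-type nitrogen gives no change at the digits printed from compound 3 to compound 4 (within the scatter) and so shows that this position has now carried an aryl ring with two halogens without any inhibition appearing. Set against the methoxy-bearing ring, the result reads no change at the digits printed from compound 2 to compound 4 (within the scatter) and, set against the compound with hydrogen on that oxygen, it reads no change at the digits printed from compound 1 to compound 4 (within the scatter) so that the whole carbamate with this ring adds nothing measurable either. No measurement given here explains why the read-out stays flat.

The compounds shown leave open whether a different kind of group on the amide-type nitrogen, such as a phenyl ring carrying an amine or a carboxylic acid, would raise the read-out. Equally open, as far as these compounds go, is whether a urea in place of the carbamate would do so.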